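The source may report more compounds than this note shows. Statements on the series, on what has been measured and on what is new or still open speak of the compounds shown alone.

Measured compounds:
- compound 1, `CC(CCOc1ccc(-c2noc(C(C)(C)C)n2)cc1)CCN1CCN(c2ccnc(N)c2)C1=O`, 55000 nM
- compound 2, `CCO/N=C/c1ccc(OCCCCN2CCN(c3ccnc(N)c3)C2=O)cc1`, > 100000 nM

Going by the values given here, in an ADME assay on RD cells (Homo sapiens) for cytotoxicity, read by MTT assay, with a stated time of 24 h (a lower number here means that less compound is tolerated, a higher number that more compound is tolerated), compound 1 gives 55000 nM, the only plain number among the two results. The other result belongs to compound 2 and is a limit of the assay, (the limit of > 100000 nM in this assay, at which 1 of the 2 values shown sits). For compound 2 this assay reports > 100000 nM, which is a limit rather than a number. Compound 3, `CCONCc1ccc(OCCC(C)CCN2CCN(c3ccnc(N)c3)C2=O)cc1`, has not been measured in this assay. It differs from compound 1 in one place: (ethoxyamino)methyl in place of 5-(tert-butyl)-1,2,4-oxadiazol-3-yl on an aromatic carbon. Among the compounds with values here, no measured pair shows this step directly. The step from compound 1 to compound 3 is expected to be modest and to go towards more compound tolerated, since compound 2, which also carries an ethoxy-bearing chain on that aromatic carbon, reaches the limit > 100000 nM. For compound 3 the estimate in this assay is 90000 nM, within 40000 nM to 200000 nM, an expected step of a 1.6-fold higher number from compound 1 to compound 3 (0.21 log units; within the scatter).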

Compound 3, half-maximal cytotoxic concentration: 7370 nM
Estimate against measurement, compound 3: 12-fold (1.09 log units) above; measured number outside the range, below it.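

In this assay, the aromatic carbon para to a large group proves sensitive to what it carries: (ethoxyamino)methyl in place of 5-(tert-butyl)-1,2,4-oxadiazol-3-yl gives a 7.5-fold lower number from compound 1 to compound 3 (0.87 log units; beyond the scatter), so less compound is tolerated. Going by these compounds alone, this is the first step that can be read at this position, and it shows that a group with no ring and one hydrogen-bond donor, at fewer heavy atoms, does not raise tolerance on this core. Nothing measured here gives a reason for the size of this step.

The compounds shown leave open whether the step goes with the loss of the ring or with the amine hydrogen of the new group. An ethoxymethyl group or a 5-methyl-1,2,4-oxadiazol-3-yl group on the same carbon would begin to separate these.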